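The compounds below may be only part of what the source reports. "The series", "measured", "known", "first", "only" and "open" are said of these compounds alone.

Values in a functional assay on PC-3 cells (Homo sapiens) for cytotoxicity, read by sulforhodamine B assay, with a stated time of 72 h; on this read-out lower numbers stand for stronger inhibition and higher numbers for weaker inhibition:
- compound 1 `COc1cc(/C=C/C(=O)/C=C(O)/C=C/c2ccc(OC(C)(C)C(=O)Nc3ccc([N+](=O)[O-])c(C(F)(F)F)c3)c(OC)c2)ccc1O`: > 100000 nM (a limit, not a number)
- compound 2 `COc1cc(/C=C/C(=O)/C=C(O)/C=C/c2ccc(OC(C)(C)C(=O)Nc3ccc(C#N)c(C(F)(F)F)c3)c(OC)c2)ccc1O`: 48100 nM

Among the compounds with values here, compound 2 holds the only actual number so far, and the limit of > 100000 nM in this assay, at which 1 of the 2 values shown sits, is all that is known of compound 1. Compound 3 `COc1cc(/C=C/C(=O)/C=C(O)/C=C/c2ccc(OC(C)(C)C(=O)Nc3ccc(F)c(C(F)(F)F)c3)c(OC)c2)ccc1O` has fluoro in place of cyano on an aromatic carbon. Within the data shown here, the single measured step, an at least 2.0-fold lower number from compound 1 to compound 2 (0.31 log units; beyond the scatter), also exchanges a group on an aromatic carbon, but it gives only a bound on its size. On that evidence, no step beyond the scatter is expected, and the estimated change is a 1.1-fold lower number from compound 2 to compound 3 (0.03 log units; within the scatter). For compound 3 the estimate is 45000 nM, with an expected range of 18000 nM to 100000 nM.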

Compound 3, half-maximal inhibitory concentration: 52100 nM
Estimate against measurement, compound 3: 1.2-fold (0.06 log units) below; measured number inside the range.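

On the aromatic carbon ortho to a trifluoromethyl group and para to a large group, cyano and fluoro cannot be told apart in this assay (a 1.1-fold higher number from compound 2 to compound 3 (0.03 log units; within the scatter)). Within the data shown here, this is the first step at this position read between two actual numbers, and it shows that two different groups here can give values within the scatter. The comparison with nitro stays unresolved (an at least 1.9-fold lower number from compound 1 to compound 3 (0.28 log units; that floor lies within the scatter)), and compound 1 has only a limit: the limit of > 100000 nM in this assay, at which 1 of the 3 values shown sits.

As far as these compounds go, whether nitro truly differs from fluoro remains open. So does whether an amine or a carboxylic acid on this carbon would move the number beyond the scatter.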